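The source may report more compounds than this note shows. Statements on the series, on what has been measured and on what is new or still open speak of the compounds shown alone.

Two members of the series have been run in an assay on membranes from HeLa cells for displacement of a labelled ligand from adenosine receptor A3 (Homo sapiens), read by scintillation counting, with a stated time of 180 min, tested at 1 uM; on this read-out higher numbers stand for more inhibition at the one concentration tested (going by the name of the read-out) and lower numbers for less inhibition. Compound 1, `CC1=C(C(=O)CC(C)C)C(c2ccoc2)NC(=O)N1`, gives 18%. Compound 2, `CCC(CC)OC(=O)C1=C(C)NC(=O)NC1c1ccco1`, gives 1%, the lower of the two numbers; the gap to compound 1 is beyond the scatter. For the measured compounds named here, the two differ in more than one place, so their values show only that the ester-bearing compound 2 sits well under compound 1.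

Compound 3, `CCC(CC)OC(=O)C1=C(C)NC(=O)NC1c1ccoc1`, is the next candidate in this assay. Its change from compound 2 is furan-3-yl in place of furan-2-yl on a saturated ring carbon. Going by the values given here, the same furan-3-yl ring is present in compound 1, which gives the higher number, but no single-change step isolates that ring in the measured pairs.

The step from compound 2 to compound 3 is expected to be small and upward, about a number 7 percentage points higher from compound 2 to compound 3 (within the scatter), within the scatter. Compound 3 is thus estimated at 8%, with a range from -5% to 25%.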

Compound 3, a percentage reported as inhibition, at one concentration (the size of the read-out at that concentration, not a potency): 5%
Compound 3: the middle estimate sits 3 percentage points above what was measured; measured number inside the range.
By their numbers in this assay, from the lowest: compounds 2 and 3 (each within the scatter of the next); then compound 1.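

In this assay, furan-3-yl in place of furan-2-yl on the saturated ring carbon gives a number 4 percentage points higher from compound 2 to compound 3 (within the scatter), so with the (pentan-3-yl)oxy group on the carbonyl carbon, this position does not separate the two furans. For the compounds shown here, with furan-3-yl held constant, (pentan-3-yl)oxy in place of isobutyl on the carbonyl carbon gives a number 13 percentage points lower from compound 1 to compound 3 (beyond the scatter), the first single-place step beyond the scatter. The higher number of compound 1 therefore goes with its isobutyl group and not with the furan-3-yl ring, which compound 3 also carries. Nothing available gives a reason for either step.

Open, on these data alone, is whether the two furans stay this close with isobutyl on the carbonyl carbon. Also open, as far as these compounds go, is whether a phenyl ring on the saturated ring carbon, or an amine or longer chain on the carbonyl carbon, would move the number.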